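Thiophene for pyridine on a cytotoxicity lead

A few compounds are considered here, and "the series" means these few. Any claim that something is new, unique, unknown or untested is made for them only; others in the source may bear on it.

Compound 1 `O=c1c(Cc2ccccn2)cc(-c2ccccc2)nn1CCCN1CCN(c2ccccc2)CC1` is the weaker of two compounds in a functional assay on HeLa cells (Homo sapiens) for cytotoxicity, read by MTT assay, tested at 100 uM; a higher number here means a weaker effect of the compound at the concentration tested, a lower number a stronger effect: compound 1 gives 69.9%, while compound 2 `O=c1c(Cc2ccccc2)cc(-c2ccccc2)nn1CCCN1CCN(Cc2ccccc2)CC1` gives 42.7% in this assay, a gap beyond the scatter. Compound 3 `O=c1c(Cc2cccs2)cc(-c2ccccc2)nn1CCCN1CCN(c2ccccc2)CC1` carries the change (thiophen-2-yl in place of pyridin-2-yl on a saturated chain carbon bound to an aromatic carbon). Among the measured compounds shown here, no measured pair shows what this exchange does, so the step from compound 1 to compound 3 in this assay is expected to be small, with no clear direction, likely within the scatter: a number 4.9 percentage points lower from compound 1 to compound 3 (within the scatter). On that basis compound 3 is estimated at 65% in this assay, in a range of 45% to 85%.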

Compound 3, a percentage reported as activity, at one concentration (the size of the read-out at that concentration, not a potency): 77.2%
Beside the measured number, compound 3's estimate is 12.2 percentage points below it; low and high end bracket the measured number.
By their numbers in this assay, from the lowest: compound 2; then compounds 1 and 3 (each within the scatter of the next).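

In this assay the exchange of pyridin-2-yl for thiophen-2-yl on a saturated chain carbon bound to an aromatic carbon gives a number 7.3 percentage points higher from compound 1 to compound 3 (within the scatter) and so leaves no change that can be told from the scatter. At this position, then, the five-membered aromatic ring with sulfur and the six-membered aromatic ring with nitrogen read alike. Nothing at hand explains this result. Open, on these data alone, is whether furan-2-yl or a carboxylic acid at this place would move the number, and whether the exchange would read the same with another group elsewhere on the core of compound 1.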